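A few compounds are considered here, and "the series" means these few. Any claim that something is new, unique, unknown or untested is made for them only; others in the source may bear on it.

Compounds measured in an assay on cells for inhibition of S-adenosylmethionine decarboxylase proenzyme (Homo sapiens), read by mass spectrometry, at pH 7.2, tested at 180 uM; a higher number here means more inhibition at the concentration tested (going by the name of the read-out), a lower number less inhibition:

Compound 1, `Cc1nc(N)nc(Nc2cc(Cl)cc(Cl)c2)c1C`, gives 25%.
Compound 2, `Cc1cc(Nc2cc(Cl)cc(C#N)c2)nc(N)n1`, gives 29%.
Compound 3, `C=CCOc1cc(Br)cc(Nc2cc(C)nc(N)n2)c1`, gives 28%.

Compound 2 holds the highest of the three numbers in this assay, yet compound 3 and compound 1 both sit within the usual scatter of it, so the three compounds cannot be set apart from one another on these numbers. Compound 4, `Cc1cc(Nc2cc(Cl)cc(-c3ccsc3)c2)nc(N)n1`, has not yet been measured in this assay. It differs from compound 2 in one place: thiophen-3-yl in place of cyano on an aromatic carbon. For the measured compounds named here, no measured pair shows this change, so nothing here tells its size or direction. The step of a number 1 percentage points higher from compound 2 to compound 4 (within the scatter) is expected to stay within the scatter. Compound 4 is therefore estimated at 30%, with a range from 15% to 50%.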

Compound 4, a percentage reported as inhibition, at one concentration (the size of the read-out at that concentration, not a potency): 30%
Estimate against measurement, compound 4: no gap at the digits printed, within the range that was stated.
By their numbers in this assay, from the lowest: compounds 1, 3, 2 and 4 (each within the scatter of the next).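

In this assay, replacing cyano with thiophen-3-yl on this aromatic carbon, meta to the chloro group, is a step of a number 1 percentage points higher from compound 2 to compound 4 (within the scatter). The position therefore accepts a five-membered aromatic ring of 5 heavy atoms in place of a group of 2 heavy atoms, with no difference these numbers can separate. Nothing available explains this result.

On these data alone, it remains open whether an amine or a carboxylic acid at this position would give a number beyond the scatter of compound 2. The same question stands for a longer chain here.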